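Amide Substituent Swap: Propyl to 4-Chlorobenzyl

The compounds below may be only part of what the source reports. "The series", "measured", "known", "first", "only" and "open" are said of these compounds alone.

Compound 1, `C=CC1=C(C(=O)NC2CCCCC2)C(c2ccc(OC)c(OC)c2)OC1`: 7490 nM
Compound 2, `C=CC1=C(C(=O)NCCC)C(c2ccc(OC)c(OC)c2)OC1`: > 100000 nM

Two measured compounds share one core and differ only in the group on the amide nitrogen. In a functional assay on QGY7701 cells (Homo sapiens) for cytotoxicity, read by MTT assay, with a stated time of 24 h (a higher number here means a weaker inhibitor, a lower number a stronger inhibitor), compound 1 gives 7490 nM. Compound 2 reaches only a limit of this assay, > 100000 nM, so no exact number is known for it. Among the compounds with values here, the single measured step, an at least 13-fold higher number from compound 1 to compound 2 (1.12 log units; beyond the scatter), is large, and its true size is uncertain since compound 2 sits at the limit of > 100000 nM in this assay, at which 1 of the 2 values shown sits. Compound 2 is thus the weaker of the two measured compounds and stands at the edge of what this assay can report.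

Compound 3, `C=CC1=C(C(=O)NCc2ccc(Cl)cc2)C(c2ccc(OC)c(OC)c2)OC1`, differs from compound 2 by 4-chlorophenyl in place of ethyl on a saturated chain carbon bound to an amide-type nitrogen. Within the data shown here, no measured step covers this exact change. Among the measured compounds shown here, the only comparison in hand, an at least 13-fold higher number from compound 1 to compound 2 (1.12 log units; beyond the scatter), shows the propyl amide far weaker than the cyclohexyl amide. For compound 3, a step toward lower numbers, an at least 5.0-fold lower number from compound 2 to compound 3 (0.69 log units; beyond the scatter), is expected, though with wide uncertainty. Compound 3 is estimated at about 20000 nM, within 4000 nM to 100000 nM.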

Compound 3, half-maximal inhibitory concentration: > 100000 nM
Compound 3 was reported as a limit (the forecaster's own chance of this, stated with the estimate: 35%); middle value at least 5.0-fold (0.69 log units) away from the limit.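

In this assay compound 3 gives > 100000 nM, which is a limit of the assay and not an exact number. Placing 4-chlorobenzyl in place of cyclohexyl on the amide-type nitrogen gives an at least 13-fold higher number from compound 1 to compound 3 (1.12 log units; beyond the scatter), a large step, so a group carrying an aromatic ring and a chlorine does not restore the lower number seen with cyclohexyl, and a second, quite different group now falls far short of compound 1. The step from compound 2 to compound 3 cannot be read, and the data therefore cannot say whether 4-chlorophenyl in place of ethyl changes anything at all, as both compounds sit at the same ceiling: the limit of > 100000 nM in this assay, at which 2 of the 3 values shown sit.

Among the three amides shown, only cyclohexyl gives a measurable number, but it remains open whether this belongs to cyclohexyl alone or would also appear with a cyclopentyl ring, a plain benzyl without chlorine, or a branched chain such as tert-butyl. As far as these compounds go, it is also open how an amine or a carboxylic acid carried on this amide substituent would read.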